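This account rests on a few compounds, and the source may have more. Where it says the series, first, only, none or still open, it means among the compounds named here.

Of the compounds shown here, three have been measured in an assay for inhibition of HSP60/HSP10 (Homo sapiens), with a stated time of 60 min; on this read-out lower numbers stand for stronger inhibition and higher numbers for weaker inhibition. Compound 1 `O=C(Nc1ccccc1)c1cc(Br)ccc1O` reaches only a limit of this assay, > 100000 nM. Compound 3 `O=C(Nc1ccc(Sc2nc3ccccc3s2)cc1)c1ccccc1O` likewise gives only a limit, > 100000 nM. Among the measured compounds shown here, compound 2 `O=C(Nc1ccc(Sc2nc3ccccc3s2)c(Cl)c1)c1cccc(Br)c1O` gives 6900 nM in this assay, the only true number among the three. The other two values sit at a limit: the limit of > 100000 nM in this assay, at which 2 of the 3 values shown sit. Compound 4 `O=C(Nc1ccc(Sc2nc3ccccc3s2)c(Cl)c1)c1cc(Br)cc(Br)c1O` differs from compound 2 by bromo in place of hydrogen on an aromatic carbon. For the measured compounds named here, no two measured compounds differ in a single place, so no measured step guides this change. The expected step of a 1.7-fold lower number from compound 2 to compound 4 (0.24 log units; within the scatter) is a modest gain, barely beyond the scatter. Compound 4 is therefore estimated at 4000 nM, with a range from 1500 nM to 15000 nM.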

Compound 4, half-maximal inhibitory concentration: 4200 nM
For compound 4 the middle estimate is 1.1-fold (0.02 log units) below the measured one; the range from low to high includes it.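

With bromo on the aromatic carbon para to the hydroxy group, this assay gives a 1.6-fold lower number from compound 2 to compound 4 (0.22 log units; within the scatter). Among the compounds shown here, this is the first comparison of compounds that differ in one place, and it shows that compound 2 and compound 4 cannot be told apart at this position: the 3,5-dibromo-2-hydroxyphenyl group reads the same as the 3-bromo-2-hydroxyphenyl group. Nothing in the data offers an explanation for this result. Going by these compounds, whether a chloro group, an amine or a carboxylic acid on this carbon would also read the same remains open. So does the effect of bromo here on a core without the chloro group.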